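The compounds below may be only part of what the source reports. "The series", "measured", "known", "first", "only" and "open" are said of these compounds alone.

Working notes on the series, read out in a functional assay on HT-29 cells (Homo sapiens) for antiproliferative activity, with a stated time of 48 h; on this read-out lower numbers stand for an effect already at smaller amounts and higher numbers for an effect only at larger amounts of compound. Compound 1 `Nc1ccc(NC(=O)CCCCCCC(=O)NO)cc1` gives 18000 nM, compound 2 `O=C(CCCCCCC(=O)Nc1ccc(Cl)cc1)NO` gives 2100 nM, and compound 3 `CN(C)c1ccc(NC(=O)CCCCCCC(=O)NO)cc1` gives 3150 nM. Compound 3 therefore lies within the scatter of compound 2 and clearly under compound 1.

Next is compound 4 `O=C(CCCCCCC(=O)Nc1ccc([N+](=O)[O-])cc1)NO`, with no value yet in this assay. The change is nitro in place of dimethylamino on an aromatic carbon, para to a large group.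

Going by the values given here, no measured step involves nitro, so the evidence is indirect. Chloro in place of amino gave an 8.6-fold lower number from compound 1 to compound 2 (0.93 log units; beyond the scatter), and dimethylamino in place of amino gave a 5.7-fold lower number from compound 1 to compound 3 (0.76 log units; beyond the scatter). Dimethylamino in place of chloro gave only a 1.5-fold higher number from compound 2 to compound 3 (0.18 log units; within the scatter). Among these three compounds, only compound 1 stands apart, and a single pair within the scatter is thin support for any rule.

With that pair as the closest guide, no step beyond the scatter is expected in either direction, though the range is kept wide. The estimated step is a 1.1-fold lower number from compound 3 to compound 4 (0.05 log units; within the scatter). For compound 4 the expected value is 2800 nM, with an estimated range of 1100 nM to 7500 nM.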

Compound 4, half-maximal effective concentration: 76000 nM
Compound 4: the middle estimate sits 27-fold (1.43 log units) below what was measured; the whole stated range lies below it.
By their numbers in this assay, from the lowest: compounds 2 and 3 (each within the scatter of the next); then compound 1; then compound 4.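

In this assay, going by these compounds alone, the aromatic carbon para to a large group turns out to be far less tolerant than the earlier compounds suggested, since chloro and dimethylamino sat within the scatter of each other, whereas nitro brings large steps from both (a 24-fold higher number from compound 3 to compound 4 (1.38 log units; beyond the scatter); a 36-fold higher number from compound 2 to compound 4 (1.56 log units; beyond the scatter)). The amino group had been the only one standing apart, and nitro now goes past it as well (a 4.2-fold higher number from compound 1 to compound 4 (0.63 log units; beyond the scatter)), so compound 4 has the highest number of the series, beyond the scatter of each other compound, and a single change at this place spans the whole range seen so far. Nothing measured in these notes accounts for how far nitro differs from the other three groups, so the size of these steps stays an observation without an explanation.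

From the compounds shown here alone, whether the high number belongs to nitro alone, or would also appear with a nitrile, a carboxylic acid or a methoxy group at this place, stays open. Going by these compounds, it is equally open whether the same order of groups would hold with a longer chain on the shared core.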